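Chloro-Methoxy Arylsulfonyl Variant of a Weak Sulfonamide Series

This account rests on a few compounds, and the source may have more. Where it says the series, first, only, none or still open, it means among the compounds named here.

Compound 3 `O=S(=O)(Nc1ccc(-c2nc3ccccc3o2)cc1)c1ccccc1O` reaches only the limit of an assay on cells for inhibition of HSP60/HSP10 (Homo sapiens), with a stated time of 60 min (on this read-out lower numbers stand for stronger inhibition and higher numbers for weaker inhibition), giving > 100000 nM. Compound 1 `COc1ccc(S(=O)(=O)Nc2ccc(-c3nc4ccccc4o3)cc2)cc1` likewise sits at a limit, > 100000 nM, a point noted in the limit of > 100000 nM in this assay, at which 2 of the 3 values shown sit. Compound 2 `O=S(=O)(Nc1ccc(-c2nc3ccccc3o2)cc1)c1cccc(Cl)c1` gives an actual number, 54000 nM in this assay. The step of an at least 1.8-fold higher number from compound 2 to compound 3 (0.26 log units; that floor lies within the scatter) is thus read only against a limit, as is a step that the two limits leave unreadable from compound 1 to compound 3, and the step of an at least 1.8-fold lower number from compound 1 to compound 2 (0.26 log units; that floor lies within the scatter) is also only a floor. Compound 4 `COc1ccc(Cl)cc1S(=O)(=O)Nc1ccc(-c2nc3ccccc3o2)cc1` carries 5-chloro-2-methoxyphenyl in place of 2-hydroxyphenyl on a sulfonyl sulfur. Since compound 2 gave a measurable 54000 nM with a 3-chlorophenyl on the sulfonyl sulfur, compound 4 is expected to move by an at least 1.2-fold lower number from compound 3 to compound 4 (0.09 log units; that floor lies within the scatter). Compound 4 is estimated at 80000 nM, between 30000 nM and 200000 nM, with a real chance that this assay again reports only a limit.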

Compound 4, half-maximal inhibitory concentration: > 100000 nM
Compound 4 was reported as a limit (the forecaster's own chance of this, stated with the estimate: 50%); middle value at least 1.2-fold (0.09 log units) from the limit.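

In this assay compound 4 gives > 100000 nM, which is a limit and not a number. Methoxy in place of hydrogen on an aromatic carbon gives an at least 1.8-fold higher number from compound 2 to compound 4 (0.26 log units; that floor lies within the scatter), so a chlorine on the aryl group at this sulfonyl sulfur does not secure an actual number, and compound 2 remains the only compound here that has one. The series now sits mostly at the edge of the read-out: the limit of > 100000 nM in this assay, at which 3 of the 4 values shown sit.

The steps to compound 4 from compound 1 and from compound 3 cannot be read, as both ends are limits. On these data alone, whether an amine or a carboxylic acid on this aryl group would give an actual number stays open.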